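The compounds below may be only part of what the source reports. "The series", "measured", "known", "first", "only" and "open" are said of these compounds alone.

Measured so far in an assay on membranes from brain for displacement of a labelled ligand from Sigma non-opioid intracellular receptor 1 (Cavia porcellus), read by scintillation counting, with a stated time of 120 min; on this read-out higher numbers stand for weaker inhibition and lower numbers for stronger inhibition:
compound 1 `COC1Cc2c(csc2-c2ccccc2)C2(CCN(Cc3ccccc3)CC2)O1` gives 1 nM;
compound 2 `COC1Cc2c(csc2-c2ccc(-c3ccccc3)cc2)C2(CCN(Cc3ccccc3)CC2)O1` gives 30 nM;
compound 3 `c1ccc(CN2CCC3(CC2)OCCc2c(-c4ccccc4)csc23)cc1` gives 1.6 nM.

Compound 1 and compound 2 differ in one place: hydrogen in place of phenyl on an aromatic carbon. That change gave a 30-fold lower number from compound 2 to compound 1 (1.48 log units; beyond the scatter). Compound 3 shares the spiro-piperidine and benzyl parts with compound 1, and their two values lie within the usual scatter of each other; how the core of compound 3 differs from that of compound 2 is not broken down here.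

Compound 4 `c1ccc(CN2CCC3(CC2)OCCc2ccsc23)cc1` is not yet measured. It differs from compound 3 by hydrogen in place of phenyl on an aromatic carbon. This is the same kind of change as from compound 2 to compound 1, but not the same: there the phenyl left a six-membered aromatic ring of carbon only, para to a large group, here it leaves a five-membered aromatic ring with one sulfur, part of a fused system of three rings. The earlier step removed an outer phenyl from a biphenyl; here the only phenyl on the thiophene is removed, so the earlier step is weak support for the direction. The expected step in this assay is a 6.3-fold higher number from compound 3 to compound 4 (0.80 log units; beyond the scatter), a moderate loss, because the scaffold of compound 3 at 1.6 nM keeps the benzyl-piperidine and spiro parts, which are expected to retain much of the binding. Compound 4 is expected to give about 10 nM, with a range of 2 nM to 50 nM.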

Compound 4, inhibition constant: 1 nM
Estimate against measurement, compound 4: 10-fold (1.00 log units) above; measured number outside the range, below it.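

In this assay, hydrogen in place of phenyl on an aromatic carbon gives a 1.6-fold lower number from compound 3 to compound 4 (0.20 log units; within the scatter). The size of this change does not carry from one core to the other: the same change on two cores in this assay, a 30-fold lower number (1.48 log units; beyond the scatter) from compound 2 to compound 1 and a 1.6-fold lower number (0.20 log units; within the scatter) from compound 3 to compound 4, 19-fold (1.27 log units) apart, beyond the scatter of two such steps. Among the compounds shown here, the step on one core is therefore no guide to the step on the other, but with a single pair per core this does not show which structural difference between the cores goes with the gap.

Still open, from the compounds shown here alone, is whether an amine or a carboxylic acid in place of that hydrogen on the core of compound 4 would keep the value. Also open, going by these compounds, is how the same change behaves with a longer chain in place of the benzyl group.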